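Branching the Chain on the Ring Nitrogen

The source may hold more compounds than are shown below. What is called first, only, known or untested is meant among the compounds shown, and "the series" means these compounds.

Compound 3 `CCCn1cnc2c(NC3CC3)ncnc21` holds the lowest of the two single numbers in a functional assay on the whole organism for antagonist activity, with Rattus norvegicus as the target (on this read-out higher numbers stand for an effect only at larger amounts of compound and lower numbers for an effect already at smaller amounts), giving 6 mg/kg. Its nearest neighbour is compound 1 `c1nc(NC2CC2)c2ncn(CC3CCC3)c2n1`, which gives 10 mg/kg. Going by the values given here, the only measured step between these two is a 1.7-fold lower number from compound 1 to compound 3 (0.22 log units; within the scatter). Compound 2 `CC(C1CC1)n1cnc2c(NC3CC3)ncnc21` gives 2 mg/kg; 4.5 mg/kg; 12.5 mg/kg (3 entries); these repeated entries, (the several entries of compound 2 in this assay, 2 mg/kg; 4.5 mg/kg; 12.5 mg/kg (3 entries)), show how wide the spread of one compound can be in this assay. Compound 4 `CC(C)n1cnc2c(NC3CC3)ncnc21` differs from compound 3 by isopropyl in place of propyl on an aromatic nitrogen. Among the compounds with values here, no measured step turns a straight chain on the ring nitrogen into a branched one, so the guide is the within-scatter step from compound 1 to compound 3 together with the spread of compound 2. Compound 4 is therefore expected to show no step beyond the scatter, a 1.2-fold lower number from compound 3 to compound 4 (0.08 log units; within the scatter). The estimate for compound 4 is 5 mg/kg, with a range from 2 mg/kg to 12 mg/kg.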

Compound 4, dose for half-maximal effect: 4 mg/kg
Compound 4: middle estimate off by 1.3-fold (0.10 log units), on the high side; low and high end bracket the measured number.
By their numbers in this assay, from the lowest: compounds 4, 3 and 1 (each within the scatter of the next, the first and the last beyond it).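

Isopropyl in place of propyl on the aromatic nitrogen gives a 1.5-fold lower number from compound 3 to compound 4 (0.18 log units; within the scatter) and so shows that branching there makes no difference that can be told from the scatter in this assay. Isopropyl in place of cyclobutylmethyl gives a 2.5-fold lower number from compound 1 to compound 4 (0.40 log units; beyond the scatter) as the first step at this position to pass the scatter, though only modestly. Even that step needs caution, since a single compound can spread widely here: the several entries of compound 2 in this assay, 2 mg/kg; 4.5 mg/kg; 12.5 mg/kg (3 entries). As far as these compounds go, what a tert-butyl group or a longer chain carrying an amine would do on this nitrogen stays open.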